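Bromo in place of hydrogen on the phenyl of compound 1

The source may report more compounds than this note shows. Statements on the series, on what has been measured and on what is new or still open speak of the compounds shown alone.

Measured compounds:
compound 1 `CSc1ccc(Cc2nn(-c3ccccc3)c(=O)c3ccccc23)cc1` — > 100000 nM (a limit)
compound 2 `C=CCn1nc(Cc2ccc(Cl)cc2)c2ccccc2c1=O` — 2600 nM
compound 3 `Cn1nc(Cc2ccccc2Cl)c2ccccc2c1=O` — 1400 nM

In a functional assay on aorta with Alpha-1D adrenergic receptor (Rattus norvegicus) as the target (on this read-out higher numbers stand for an effect only at larger amounts of compound and lower numbers for an effect already at smaller amounts), compound 1 gives only > 100000 nM, which is a limit of the assay and not a number. Compound 2 gives 2600 nM in this assay, and compound 3 gives 1400 nM; each differs from compound 1 in more than one place, so no single change between them is counted.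

Compound 4 `CSc1ccc(Cc2nn(-c3ccc(Br)cc3)c(=O)c3ccccc23)cc1` differs from compound 1 in one place: bromo in place of hydrogen on an aromatic carbon — bromo in place of hydrogen on an aromatic carbon. Going by the values given here, no measured pair shows the effect of this change, and compound 1 sits at the limit of > 100000 nM in this assay, at which 1 of the 3 values shown sits, so there is no number to move from. The expectation for compound 4 is that the step of an at least 1.4-fold lower number from compound 1 to compound 4 (0.15 log units; that floor lies within the scatter) leaves it weak, with a fair chance that again only a limit is reported. For compound 4 the estimate is 70000 nM, between 10000 nM and 300000 nM.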

Compound 4, half-maximal effective concentration: > 100000 nM
Compound 4 ended at the assay's limit; the forecaster's own chance of this, stated with the estimate: 60%; at least 1.4-fold (0.15 log units) between middle value and limit.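

In this assay compound 1 gives > 100000 nM, a limit of the assay. Compound 4 gives > 100000 nM, also a limit, so the step from phenyl to 4-bromophenyl cannot be read. The compounds shown leave open whether this bromo changes the read-out at all.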